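The source may hold more compounds than are shown below. What is called first, only, known or untested is meant among the compounds shown, and "the series" means these compounds.

Compound 2 `Cc1ccc(S(=O)(=O)c2cnc3cc(Cl)ccc3c2N2CCC(C)CC2)cc1C` is the starting point of this step. In an assay on isolated protein for displacement of a labelled ligand from metabotropic glutamate receptor 5 (Homo sapiens), with a stated time of 60 min, tested at 1 uM (on this read-out lower numbers stand for less inhibition and higher numbers for more inhibition at the one concentration tested (going by the name of the read-out)), compound 2 gives 86%. Two near relatives share its core. Compound 1 `CC1CCN(c2c(S(=O)(=O)c3ccc(C#N)cc3)cnc3c(F)cccc23)CC1` gives in this assay 86%, and compound 3 `Cc1ccc(S(=O)(=O)c2cnc3cc(F)ccc3c2N2CCC(C)CC2)cc1C` gives 90%. The only single-point step among these three runs from compound 2 to compound 3, where a fluoro replaces a chloro on an aromatic carbon, and it amounts to a number 4 percentage points higher from compound 2 to compound 3 (within the scatter). On the numbers shown, compound 2 stands level with compound 1 at the digits printed, the two together at the low end of three readings, and its furthest neighbour is compound 3, still within the scatter.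

Compound 4 `COc1ccc(S(=O)(=O)c2cnc3cc(Cl)ccc3c2N2CCC(C)CC2)cc1Cl` differs from compound 2 in one place: 3-chloro-4-methoxyphenyl in place of 3,4-dimethylphenyl on a sulfonyl sulfur. Among the compounds with values here, no measured step touches the aryl group on the sulfonyl sulfur; the one step that exists, a number 4 percentage points higher from compound 2 to compound 3 (within the scatter), concerns the halogen on the core and does not reach beyond the scatter. There is therefore no measured ground for expecting a step beyond the scatter in this assay for compound 4. The expected reading for compound 4 is 83%, within a range from 62% to 95%, which is expected to mean a step of a number 3 percentage points lower from compound 2 to compound 4 (within the scatter).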

Compound 4, a percentage reported as inhibition, at one concentration (the size of the read-out at that concentration, not a potency): 93%
Compound 4: middle estimate off by 10 percentage points, on the low side, and the stated range covers the measured number.
By their numbers in this assay, from the lowest: compounds 1, 2, 3 and 4 (each within the scatter of the next).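

Within the data shown here, compound 4 gives the first reading on a change at the aryl group on the sulfonyl sulfur: in this assay, 3-chloro-4-methoxyphenyl in place of 3,4-dimethylphenyl amounts to a number 7 percentage points higher from compound 2 to compound 4 (within the scatter). The earlier step concerned only the halogen on the core, so this result extends the picture to a second place, where a group containing oxygen and chlorine replaces one of carbon only and the step still stays within the scatter. Nothing given here bears on why the reading of compound 4 falls where it does.

The step from compound 2 to compound 4 alters both substituents on the aryl ring at once, so the share of the chloro and the share of the methoxy cannot be told apart, and every reading in this assay comes from one concentration and gives no potency. On these data alone, it also remains open whether a carboxylic acid, a dimethylamino group or a longer alkoxy chain on this aryl ring, or a pyridine ring in its place on the sulfonyl sulfur, would produce a step beyond the scatter.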